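Amide variation on a shared core: all cytotoxicity values at the limit

The compounds below may be only part of what the source reports. "The series", "measured", "known", "first", "only" and "open" are said of these compounds alone.

Compound 1 `COc1ccc(OC)c(-c2cc(-c3ccc(C(=O)N4CCCCC4)s3)on2)c1` gives > 30000 nM in a functional assay on A549 cells (Homo sapiens) for cytotoxicity, read by XTT assay, with a stated time of 72 h (a higher number here means a weaker inhibitor, a lower number a stronger inhibitor), a limit of the assay and not a number.
Compound 2 `COc1ccc(OC)c(-c2cc(-c3ccc(C(=O)NC4CC4)s3)on2)c1` gives > 30000 nM in this assay, again a limit.
Compound 3 `CCCN(C)C(=O)c1ccc(-c2cc(-c3cc(OC)ccc3OC)no2)s1` gives > 30000 nM in this assay, also a limit.

Compound 3 therefore stands where every measured compound stands: at the limit of > 30000 nM in this assay, at which 3 of the 3 values shown sit, so there is no number to place it against the others. The three measured steps, a step that the two limits leave unreadable from compound 1 to compound 2, a step that the two limits leave unreadable from compound 1 to compound 3 and a step that the two limits leave unreadable from compound 2 to compound 3, each join two limits and so carry no readable size in either direction. They show only that three different amide substituents on the carbonyl carbon all leave the read-out at the limit.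

Compound 4 `CCN(CC)C(=O)c1ccc(-c2cc(-c3cc(OC)ccc3OC)no2)s1` differs from compound 3 by diethylamino in place of methyl(propyl)amino on a carbonyl carbon. This change stays within the same kind of substituent that the measured steps already cover without any readable effect, so no step beyond the scatter is expected, and the step from compound 3 to compound 4 is estimated as a step that the limit leaves unreadable from compound 3 to compound 4. Compound 4 is expected to give about 50000 nM, in a range from 30000 nM to 100000 nM, most likely reported again as a limit.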

Compound 4, half-maximal inhibitory concentration: 11000 nM
Compound 4: middle estimate off by 4.5-fold (0.66 log units), on the high side, outside the stated range (below it).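

In this assay, among the compounds shown here, the amide substituent on the carbonyl carbon proves able to move the read-out, which the earlier compounds could not show: the steps are an at least 2.7-fold lower number from compound 3 to compound 4 (0.43 log units; beyond the scatter), an at least 2.7-fold lower number from compound 2 to compound 4 (0.43 log units; beyond the scatter) and an at least 2.7-fold lower number from compound 1 to compound 4 (0.43 log units; beyond the scatter). Diethylamino and methyl(propyl)amino have the same atoms and no ring, so a different arrangement of those atoms is enough for a step beyond the scatter. The steps among compound 1, compound 2 and compound 3 still cannot be read, as those compounds remain at a limit: the limit of > 30000 nM in this assay, at which 3 of the 4 values shown sit.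

As far as these compounds go, the full size of the new steps stays open, since each starts from a limit. Also open, from the compounds shown here alone, is whether dipropylamino, a longer chain, or morpholino, a ring holding oxygen, would lower the number further on the shared core.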